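Ethoxy in Place of Ethylsulfanyl on a Potent Compound

The source may report more compounds than this note shows. Statements on the series, on what has been measured and on what is new or still open speak of the compounds shown alone.

Among the compounds with values here, in a functional assay on HL-60 cells (Homo sapiens) for inhibition, read by resazurin assay, with a stated time of 72 h (on this read-out higher numbers stand for weaker inhibition and lower numbers for stronger inhibition), compound 2 `CCSc1ccc(C2C(O)C(=O)N2c2cc(OC)c(OC)c(OC)c2)cc1` gives 16 nM, the lowest of the three numbers measured so far. Compound 1 `CCSc1ccc(C2C(Oc3ccccc3)C(=O)N2c2cc(OC)c(OC)c(OC)c2)cc1` gives 508 nM, and compound 3 `C=CC1C(=O)N(c2cc(OC)c(OC)c(OC)c2)C1c1ccc(SCC)cc1` gives 320 nM. Compound 4 `CCOc1ccc(C2C(O)C(=O)N2c2cc(OC)c(OC)c(OC)c2)cc1` keeps the whole of compound 2 except for one group, with ethoxy in place of ethylsulfanyl on an aromatic carbon. Within the data shown here, no measured step touches that group, so the data hold no direct measure of this swap. All three steps change a saturated ring carbon instead. There, a 32-fold lower number from compound 1 to compound 2 (1.50 log units; beyond the scatter) and a 20-fold higher number from compound 2 to compound 3 (1.30 log units; beyond the scatter) are both large, while a 1.6-fold lower number from compound 1 to compound 3 (0.20 log units; within the scatter) stays within the scatter. Compound 4 keeps the hydroxy group of compound 2, whose replacement by vinyl gave a 20-fold higher number from compound 2 to compound 3 (1.30 log units; beyond the scatter), so neither large step is repeated here. The expected change in this assay is therefore small, a 1.6-fold higher number from compound 2 to compound 4 (0.19 log units; within the scatter), probably within the scatter. The estimate for compound 4 is 25 nM, with an expected range from 8 nM to 80 nM.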

Compound 4, half-maximal inhibitory concentration: 11 nM
The estimate for compound 4 lay 2.3-fold (0.36 log units) above the measured number, and the stated range covers the measured number.
By their numbers in this assay, from the lowest: compounds 4 and 2 (each within the scatter of the next); then compounds 3 and 1 (each within the scatter of the next).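

In this assay, this position can finally be read directly: the change gives a 1.5-fold lower number from compound 2 to compound 4 (0.16 log units; within the scatter), so ethoxy can stand in place of ethylsulfanyl, para to a large group, with no step beyond the scatter. With the hydroxy group kept, this step is much smaller than the large ones at the saturated ring carbon, such as a 20-fold higher number from compound 2 to compound 3 (1.30 log units; beyond the scatter). No measurement here explains why the two groups read alike.

The compounds shown leave open how a longer chain such as propoxy, or an amine such as dimethylamino, would read at this place. From the compounds shown here alone, it also remains open whether ethoxy would read like ethylsulfanyl alongside the phenoxy group of compound 1 or the vinyl group of compound 3.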